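Swapping the whole five-membered ring on compound 1

A few compounds are considered here, and "the series" means these few. Any claim that something is new, unique, unknown or untested is made for them only; others in the source may bear on it.

Compound 1 `CC(=O)c1ccc(-c2cncc(Cl)c2N2CCC3(CCNC3=O)CC2)s1` is tested in a functional assay on MV4-11 cells (Homo sapiens) for inhibition, read by resazurin assay, with a stated time of 72 h (a higher number here means a weaker inhibitor of growth, a lower number a stronger inhibitor of growth), where compound 1 gives 1440 nM. Among the three compounds measured so far, compound 1 stands second highest. Compound 2 `O=C1NCCC12CCN(c1c(Cl)cncc1-c1ccc(-c3ccccc3)s1)CC2` gives 960 nM, and the step of a 1.5-fold lower number from compound 1 to compound 2 (0.18 log units; within the scatter) lies within the scatter. Compound 3 `O=C1NCCC12CCN(c1c(Cl)cncc1-c1ccc(CN3CCCC3)s1)CC2` gives 3370 nM, a step of a 2.3-fold higher number from compound 1 to compound 3 (0.37 log units; beyond the scatter). Compound 4 `O=C1NCCC12CCN(c1c(Cl)cncc1-c1cn[nH]c1)CC2` carries a different change: 1H-pyrazol-4-yl in place of 5-acetylthiophen-2-yl on an aromatic carbon. Going by the values given here, no measured step removes the 5-acetylthiophen-2-yl entirely; the two steps from compound 1 only alter the group carried on that ring, and neither moved the number far. A modest shift toward a higher number is therefore expected, a 1.8-fold higher number from compound 1 to compound 4 (0.26 log units; within the scatter). Compound 4 is expected to give about 2600 nM, between 900 nM and 7500 nM.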

Compound 4, concentration for 50% growth inhibition: 8520 nM
Compound 4: middle estimate off by 3.3-fold (0.52 log units), on the low side; measured number outside the range, above it.
By their numbers in this assay, from the lowest: compounds 2 and 1 (each within the scatter of the next); then compound 3; then compound 4.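

Putting 1H-pyrazol-4-yl in place of 5-acetylthiophen-2-yl on this aromatic carbon gives a 5.9-fold higher number from compound 1 to compound 4 (0.77 log units; beyond the scatter), the largest step yet seen from compound 1. Here, the number changes more when the whole ring goes than in either earlier step from compound 1, where only the group carried on that ring changed. This single step replaces the ring and removes the acetyl together, and no measured evidence accounts for the result. As far as these compounds go, how a plain thiophen-2-yl or a furan-2-yl compares remains open, and such a comparison could help separate the effect of the ring from that of its acetyl group.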